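The compounds below may be only part of what the source reports. "The series", "measured", "known", "first", "only" and "open" are said of these compounds alone.

Measured so far in a functional assay on LNCaP cells (Homo sapiens) for antiproliferative activity; a lower number here means a stronger inhibitor, a higher number a weaker inhibitor 

- Compound 1 `O=C(Nc1ccc(CO)cc1)Nc1ccc(-c2nc(N3C4CCC3COC4)nc(N3C4CCC3COC4)n2)cc1` gives < 0.8 nM as a limit
- Compound 2 `CC(C)Nc1nc(-c2ccc(NC(=O)Nc3ccc(N4CCN(C)CC4)cc3)cc2)nc(N2C3CCC2COC3)n1` gives 50 nM as a number

Among the measured compounds shown here, compound 2 at 50 nM holds the only true number so far in this assay and is the starting point here. Compound 3 `CN1CCN(c2ccc(NC(=O)Nc3ccc(-c4nc(C5=CCOCC5)nc(N5C6CCC5COC6)n4)cc3)cc2)CC1` differs from it in one place, on an aromatic carbon. The change is a group of 6 heavy atoms (5 carbon, 1 oxygen; one six-membered non-aromatic ring with 1 hetero atom) in place of a group of 4 heavy atoms (3 carbon, 1 nitrogen; no ring), on an aromatic carbon so that isopropylamino leaves and a six-membered non-aromatic ring enters. For the measured compounds named here, no measured pair shows this change alone, so any expectation is a judgement. Compound 1 also lacks isopropylamino and shows < 0.8 nM as a limit, which tilts the expectation towards a stronger inhibitor. The expected change is a 4.2-fold lower number from compound 2 to compound 3 (0.62 log units; beyond the scatter) in that direction. Compound 3 is expected at 12 nM with a range from 2 nM to 60 nM in this estimate.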

Compound 3, half-maximal inhibitory concentration: 25 nM
The estimate for compound 3 lay 2.1-fold (0.32 log units) below the measured number; the measured number falls inside the stated range.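

In this assay, replacing isopropylamino with the six-membered non-aromatic ring gives a 2.0-fold lower number from compound 2 to compound 3 (0.30 log units; within the scatter), so on this aromatic carbon between two ring nitrogen atoms the two groups cannot be told apart. The entering group has 0 hydrogen-bond donors where isopropylamino has 1, so a donor on this carbon is not needed for the activity seen with compound 2. Compound 1 differs from compound 3 in more than one place and its value is a limit, so it gives no direct reading of this change: the limit of < 0.8 nM in this assay, at which 1 of the 3 values shown sits.

From the compounds shown here alone, it remains open whether a ring without the double bond, such as tetrahydropyran, or a morpholine would fit this position equally well. A small primary amine or a methoxy group on the same carbon would show whether a much smaller group is also accepted here.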